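The source may hold more compounds than are shown below. What is called first, only, known or untested is meant among the compounds shown, and "the series" means these compounds.

Measured so far:
compound 1 `CCc1ccc(Cn2c(CCc3ccccc3)nnc2[C@H](NC(=O)Cc2cccnc2)c2c[nH]c3ccccc23)cc1` — 480 nM
compound 2 `COc1ccc(Cn2c(CCc3ccccc3)nnc2[C@H](NC(=O)c2cnccn2)c2c[nH]c3ccccc23)cc1` — 14 nM

In an in vitro assay on LLC-PK1 cells for displacement of a labelled ligand from growth hormone secretagogue receptor type 1 (Homo sapiens) (a higher number here means a weaker inhibitor, a lower number a stronger inhibitor), compound 2 gives the lower of the two numbers; compound 1 gives a higher number, beyond the scatter. These two differ in more than one part, so no single change is isolated by them. Compound 3 `CCc1ccc(Cn2c(CCc3ccccc3)nnc2[C@H](NC(=O)c2cnccn2)c2c[nH]c3ccccc23)cc1` differs from compound 2 by ethyl in place of methoxy on an aromatic carbon. Going by the values given here, no measured pair tests this change alone. For compound 3 the expected step of a 1.6-fold higher number from compound 2 to compound 3 (0.20 log units; within the scatter) is small, at most a slight weakening, and not beyond the scatter. Compound 3 is therefore estimated at 22 nM, with a range of 7 nM to 70 nM.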

Compound 3, half-maximal inhibitory concentration: 89 nM
Compound 3: middle estimate off by 4.0-fold (0.61 log units), on the low side; measured number outside the range, above it.
By their numbers in this assay, from the lowest: compound 2; then compound 3; then compound 1.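

In this assay the 4-methoxybenzyl group is now tested alone against 4-ethylbenzyl, and ethyl in place of methoxy on the aromatic carbon gives a 6.4-fold higher number from compound 2 to compound 3 (0.80 log units; beyond the scatter) in this series. With ethyl held constant, pyrazin-2-yl in place of (pyridin-3-yl)methyl on the carbonyl carbon gives a 5.4-fold lower number from compound 1 to compound 3 (0.73 log units; beyond the scatter), so each of the two places moves the number on its own. No measurement available here accounts for either step.

From the compounds shown here alone, whether a hydroxyl, a chlorine atom or a propyl chain on this aromatic carbon would give a number near that of compound 2 remains open. Also open, going by these compounds, is how methoxy behaves with (pyridin-3-yl)methyl on the carbonyl carbon.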